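A few compounds are considered here, and "the series" means these few. Any claim that something is new, unique, unknown or untested is made for them only; others in the source may bear on it.

Series notes, read-out: a functional assay on HCC1806 cells (Homo sapiens) for inhibition, read by sulforhodamine B assay, tested at 10 uM; a lower number here means less inhibition, a higher number more inhibition at the concentration tested (going by the name of the read-out).

Compound 1, `CN(C)c1ccc(C2CC(c3ccc(-n4cncn4)cc3)=NN2C(=O)c2ccc(F)cc2)cc1`: compound 1 gives 15.6%.
Compound 2, `CN(C)c1ccc(C2CC(c3ccc(-n4cncn4)cc3)=NN2C(=O)c2ccc(C(F)(F)F)cc2)cc1`: compound 2 gives 7%.
Compound 3, `CN(C)c1ccc(C2CC(c3ccc(-n4cncn4)cc3)=NN2C(=O)/C=C/c2ccccc2)cc1`: compound 3 gives -3.7%.

Compound 1 holds the highest of the three numbers in this assay; the gap to compound 2 is a number 8.6 percentage points lower from compound 1 to compound 2 (within the scatter), and the gap to compound 3 is a number 19.3 percentage points lower from compound 1 to compound 3 (beyond the scatter). Between compound 2 and compound 3 the step is a number 10.7 percentage points lower from compound 2 to compound 3 (beyond the scatter). All three measured steps concern the group on the carbonyl carbon; the other end of the shared core is unchanged across compound 1, compound 2 and compound 3.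

Compound 4, `CN(C)c1ccc(C2CC(c3ccc(-n4ccnc4)cc3)=NN2C(=O)c2ccc(F)cc2)cc1`, differs from compound 1 at exactly that other end: 1H-imidazol-1-yl in place of 1H-1,2,4-triazol-1-yl on an aromatic carbon. Among the measured compounds shown here, no measured pair alters this position, so none of the three steps bears directly on the change. For the measured compounds named here, the only anchor is the value of compound 1 itself, and the step from compound 1 to compound 4 is therefore expected to stay within the scatter, without a set direction: a number 1.6 percentage points lower from compound 1 to compound 4 (within the scatter).

On these data alone, on that basis compound 4 is estimated at 14%, with a range from 0% to 28%; the breadth reflects that the triazolyl-to-imidazolyl exchange is untested here.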

Compound 4, a percentage reported as inhibition, at one concentration (the size of the read-out at that concentration, not a potency): 7.1%
The estimate for compound 4 lay 6.9 percentage points above the measured number; the measured number falls inside the stated range.
By their numbers in this assay, from the lowest: compound 3; then compounds 2, 4 and 1 (each within the scatter of the next).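

Among the compounds shown here, this is the first reading at the azole end of the shared core: in this assay there is a number 8.5 percentage points lower from compound 1 to compound 4 (within the scatter), with 1H-imidazol-1-yl replacing 1H-1,2,4-triazol-1-yl on an aromatic carbon para to a large group. For the compounds shown here, the step lies within the scatter, so with the 4-fluorophenyl group held on the carbonyl carbon, this pair gives no readable difference between the two rings, and the earlier steps, all confined to the carbonyl end, could not show this. No supporting measurement bears on this result, and the pair offers no account of what the ring exchange does beyond this single reading.

Going by these compounds alone, it remains open whether the same exchange would also read within the scatter with 4-(trifluoromethyl)phenyl or 2-phenylethenyl on the carbonyl carbon, as the only pair at this position carries 4-fluorophenyl. Also open, on these data alone, is whether a group of another kind on this aromatic carbon, such as a carboxylic acid, a primary amine or a longer chain ending in a morpholine, would move the number beyond the scatter in this assay.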